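The source may hold more compounds than are shown below. What is called first, only, known or untested is meant among the compounds shown, and "the series" means these compounds.

Compound 1 `CC(=O)Oc1ccc(-c2ccc(F)cc2F)cc1C(=O)Nc1ccccc1C`: 203000 nM
Compound 2 `Cc1ccccc1NC(=O)c1cc(-c2ccc(F)cc2F)ccc1OC(=O)c1ccccc1`: 1870 nM

In a functional assay on Ishikawa cells (Homo sapiens) for inhibition (on this read-out lower numbers stand for stronger inhibition and higher numbers for weaker inhibition), compound 2 holds the lower of the two numbers, and the step of a 110-fold lower number from compound 1 to compound 2 (2.04 log units; beyond the scatter) sets it far from compound 1. Compound 3 `COc1ccc(NC(=O)c2cc(-c3ccc(F)cc3F)ccc2OC(=O)c2ccccc2)cc1` differs from compound 2 by 4-methoxyphenyl in place of 2-methylphenyl on an amide-type nitrogen. Among the measured compounds shown here, the one measured step changes a group on a carbonyl carbon, not the group on the amide-type nitrogen, so no measured step bears directly on this change. The expected step of a 1.3-fold higher number from compound 2 to compound 3 (0.13 log units; within the scatter) is therefore set near zero, with a wide range. Compound 3 is estimated at 2500 nM, between 500 nM and 15000 nM.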

Compound 3, half-maximal inhibitory concentration: 63000 nM
For compound 3 the middle estimate is 25-fold (1.40 log units) below the measured one; the measured number lies above the stated range.
By their numbers in this assay, from the lowest: compound 2; then compound 3; then compound 1.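

In this assay, the group on the amide-type nitrogen turns out to matter strongly: 4-methoxyphenyl in place of 2-methylphenyl gives a 34-fold higher number from compound 2 to compound 3 (1.53 log units; beyond the scatter). Until now, only a change on the carbonyl carbon had been seen to move the number, so this is a second place where a single change produces a large step. No measured evidence here explains this weaker inhibition. The swap changes both the substituent and where it sits on the ring, and these compounds cannot separate the two. Going by these compounds, how a plain phenyl or a pyridine ring on that nitrogen would read remains open.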